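Swapping methoxy for bromo on the aryl ring

The source may hold more compounds than are shown below. What is called first, only, known or untested is meant among the compounds shown, and "the series" means these compounds.

Measured compounds:
compound 1, `COc1ccc(-c2ccnc(Nc3ccc([N+](=O)[O-])cc3)n2)cc1`, 980 nM
compound 2, `O=[N+]([O-])c1ccc(Nc2nccc(-c3ccc(Br)cc3)n2)cc1`, 25700 nM
compound 3, `COc1ccc(-c2ccnc(Nc3cccc(OC)c3)n2)cc1`, 550 nM

In a functional assay on HeLa cells (Homo sapiens) for antiproliferative activity, read by MTT assay (a lower number here means a stronger inhibitor, a higher number a weaker inhibitor), compound 3 gives the lowest number of the three, and compound 1 sits within the scatter of it. Compound 2 lies well apart: the step of a 26-fold higher number from compound 1 to compound 2 (1.42 log units; beyond the scatter), bromo in place of methoxy on an aromatic carbon, is large and beyond the scatter. The difference between the core of compound 1 and the core of compound 3 is not broken down here.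

Compound 4, `COc1cccc(Nc2nccc(-c3ccc(Br)cc3)n2)c1`, has not yet been tested in this assay. It arises from compound 3 by bromo in place of methoxy on an aromatic carbon, the same change that turns compound 1 into compound 2, at the same place, para to a large group. The account therefore expects a step of an 18-fold higher number from compound 3 to compound 4 (1.26 log units; beyond the scatter), close to the earlier one, because the pair compound 1 to compound 2 gave a 26-fold higher number from compound 1 to compound 2 (1.42 log units; beyond the scatter). On that basis compound 4 is estimated at 10000 nM in this assay, with a likely range from 3000 nM to 40000 nM.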

Compound 4, half-maximal inhibitory concentration: 153000 nM
The estimate for compound 4 lay 15-fold (1.18 log units) below the measured number; measured number above the stated range.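

In this assay, bromo in place of methoxy gives a higher number on both cores, but the new step, a 280-fold higher number from compound 3 to compound 4 (2.44 log units; beyond the scatter), is clearly larger than the earlier one, so the size of the change does not carry over from one core to the other: the same change on two cores in this assay, a 26-fold higher number (1.42 log units; beyond the scatter) from compound 1 to compound 2 and a 280-fold higher number (2.44 log units; beyond the scatter) from compound 3 to compound 4, 11-fold (1.03 log units) apart, beyond the scatter of two such steps

Only the direction is shared by the two pairs, and on these compounds the size of the step depends on the core that carries it. Two pairs are too few to set a rule for other cores, and they do not show why the steps differ or which feature of the cores accounts for the gap.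

Compound 1 and compound 2 carry a nitro group that compound 3 and compound 4 lack. The compounds shown cannot tell what that difference means for the gap. From the compounds shown here alone, it also remains open whether a chloro group or an amine in the place of the methoxy would give steps that differ between the two cores in the same way.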